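Removing a ring methyl from a kinase inhibitor

The source may report more compounds than this note shows. Statements on the series, on what has been measured and on what is new or still open speak of the compounds shown alone.

Three compounds have been measured in an assay on isolated protein for inhibition of proto-oncogene tyrosine-protein kinase receptor Ret variant V804M (Homo sapiens), read by 33P incorporation, with stated times of 15 min and 40 min; on this read-out lower numbers stand for stronger inhibition and higher numbers for weaker inhibition:
compound 1 `O=C(Nc1ccc(Nc2ncnc3c2OCCN3)cc1)Nc1cccc(-c2ccccc2)c1`, 7590 nM
compound 2 `CC(C)(C)c1cc(NC(=O)Nc2ccc(Nc3ncnc4c3OCCN4)nc2)no1`, 180 nM
compound 3 `CN1CCCOc2c(Nc3ccc(NC(=O)Nc4cc(C(C)(C)C)on4)cc3)ncnc21`, 716 nM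

Compound 3 holds the second highest number of the three: compound 2 sits well below it, beyond the scatter, and compound 1 far above it, also beyond the scatter. Compound 4 `CC(C)(C)c1cc(NC(=O)Nc2ccc(Nc3ncnc4c3OCCCN4)cc2)no1` differs from compound 3 by one change, (hydrogen in place of methyl on a nitrogen on an aromatic ring in a ring), hydrogen in place of methyl on a nitrogen on an aromatic ring in a ring. Among the compounds with values here, no measured pair shows this change directly, so the account rests on the neighbouring compounds alone. Compound 4 is expected to come out close to compound 3, perhaps with a somewhat lower number, a step of a 1.8-fold lower number from compound 3 to compound 4 (0.25 log units; within the scatter) in this assay. The estimate for compound 4 is 400 nM, with a range from 100 nM to 1500 nM.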

Compound 4, half-maximal inhibitory concentration: 15 nM
Compound 4: middle estimate off by 27-fold (1.43 log units), on the high side; measured number below the stated range.
By their numbers in this assay, from the lowest: compound 4; then compound 2; then compound 3; then compound 1.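

Hydrogen in place of methyl on the nitrogen of the seven-membered non-aromatic ring gives a 48-fold lower number from compound 3 to compound 4 (1.68 log units; beyond the scatter) in this assay, a large step. The earlier compounds shown here could not show that this one place, three ring bonds from the ring oxygen, weighs so heavily, and here the loss of one carbon alone makes the whole difference. Nothing available explains the size of this step. From the compounds shown here alone, how an ethyl or an acetyl group on that nitrogen would read remains open, as does whether the same change would give a step of this size with a different group in place of the tert-butyl.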